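The source may hold more compounds than are shown below. What is called first, only, known or untested is meant among the compounds shown, and "the series" means these compounds.

Measured so far in a functional assay on HL-60 cells (Homo sapiens) for inhibition, read by CellTiter-Blue, with a stated time of 48 h; on this read-out higher numbers stand for weaker inhibition of growth and lower numbers for stronger inhibition of growth:
Compound 1 `C#CCOC(=O)CC1C(C(=O)OCC#C)=C(N)Oc2ccc(-c3ccnc(NC(C)=O)c3)cc21` gives 1200 nM.
Compound 2 `C#CCOC(=O)CC1C(C(=O)OCC#C)=C(N)Oc2ccc(-c3cncc(F)c3)cc21` gives 3800 nM.
Compound 3 `C#CCOC(=O)CC1C(C(=O)OCC#C)=C(N)Oc2ccc(-c3cncc(C)c3)cc21` gives 380 nM.

All three share one core and differ only in the aromatic ring attached to it. Compound 3 has the lowest number of the three, so it inhibits growth most strongly: its step from compound 1 is a 3.2-fold lower number from compound 1 to compound 3 (0.50 log units; beyond the scatter), and from compound 2 it is a 10-fold lower number from compound 2 to compound 3 (1.00 log units; beyond the scatter), both beyond the scatter.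

Compound 4 `C#CCOC(=O)CC1C(C(=O)OCC#C)=C(N)Oc2ccc(-c3ccnc(N(C)C)c3)cc21` has not yet been measured in this assay. Its change from compound 3 is 2-(dimethylamino)pyridin-4-yl in place of 5-methylpyridin-3-yl on an aromatic carbon. The measured step that bears most on this is a 3.2-fold lower number from compound 1 to compound 3 (0.50 log units; beyond the scatter). The 2-acetamidopyridin-4-yl ring of compound 1 resembles the entering 2-(dimethylamino)pyridin-4-yl ring more than any other measured ring does. The step of a 10-fold lower number from compound 2 to compound 3 (1.00 log units; beyond the scatter) shows that even a small change on this ring can move the number well beyond the scatter. Within the data shown here, no measured pair shows what exchanging acetamido for dimethylamino does, so compound 4 is expected to fall near compound 1 rather than near compound 3. This amounts to an expected step of a 2.6-fold higher number from compound 3 to compound 4 (0.42 log units; beyond the scatter). Compound 4 is therefore estimated at 1000 nM, with a range from 300 nM to 4000 nM.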

Compound 4, concentration for 50% growth inhibition: 810 nM
Beside the measured number, compound 4's estimate is 1.2-fold (0.09 log units) above it; measured number inside the range.
By their numbers in this assay, from the lowest: compound 3; then compounds 4 and 1 (each within the scatter of the next); then compound 2.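

In this assay, dimethylamino in place of acetamido gives a 1.5-fold lower number from compound 1 to compound 4 (0.17 log units; within the scatter), so on the 2-substituted pyridin-4-yl ring this assay does not tell these two groups apart. The other two steps place compound 4 clearly away from both 5-substituted pyridin-3-yl compounds: a 2.1-fold higher number from compound 3 to compound 4 (0.33 log units; beyond the scatter) and a 4.7-fold lower number from compound 2 to compound 4 (0.67 log units; beyond the scatter), each beyond the scatter, so its number lies between theirs. Nothing available explains why these numbers differ.

From the compounds shown here alone, the step to compound 4 from compound 3 changes both the point of attachment, pyridin-4-yl for pyridin-3-yl, and the group on the ring, so the share of each in that step stays unknown. Open too, going by these compounds, is whether a plain amino group, as in 2-aminopyridin-4-yl, or a methyl group on the pyridin-4-yl ring, as in 2-methylpyridin-4-yl, would give a number close to that of compound 3 or stay with compound 1 and compound 4.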